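A Methyl Group Added to Compound 1: Expected Growth Inhibition

This account rests on a few compounds, and the source may have more. Where it says the series, first, only, none or still open, it means among the compounds named here.

Compound 1 `N/C(=N\NC(=S)N1CCCCCC1)c1ccccn1` gives 50.3% in a functional assay on A-431 cells (Homo sapiens) for cytotoxicity, read by MTT assay, with a stated time of 72 h, tested at 3 uM; on this read-out higher numbers stand for more inhibition of growth at the one concentration tested and lower numbers for less inhibition of growth.
Compound 2 `N/C(=N\NC(=S)N1CCCCC1)c1ccccn1` gives 27% in this assay.
Compound 3 `Cc1cccc(/C(N)=N/NC(=S)N2CCCCC2)n1` gives 36.6% in this assay.

Compound 1 stands highest of the three measured compounds; its nearest neighbour is compound 3, at a distance beyond the scatter, and its furthest is compound 2, also beyond the scatter. How the core of compound 1 differs from that of compound 2 is not broken down here.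

Between compound 2 and compound 3 one change is made: methyl in place of hydrogen on an aromatic carbon. In this assay it produced a number 9.6 percentage points higher from compound 2 to compound 3 (within the scatter).

Compound 4 `Cc1ccnc(/C(N)=N/NC(=S)N2CCCCCC2)c1` is not yet measured. It differs from compound 1 by methyl in place of hydrogen on an aromatic carbon. This is the same kind of change as that from compound 2 to compound 3, not the same one: in compound 3 the methyl sits next to the ring nitrogen, meta to a large group, whereas in compound 4 it sits meta to a large group, opposite the ring nitrogen.

In this assay the step from compound 1 to compound 4 is expected to be a number 4.7 percentage points higher from compound 1 to compound 4 (within the scatter), a small step like the earlier one, resting on a number 9.6 percentage points higher from compound 2 to compound 3 (within the scatter). Compound 4 is therefore estimated at 55%, between 36% and 72%.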

Compound 4, percent growth inhibition at one concentration: 36.1%
The estimate for compound 4 lay 18.9 percentage points above the measured number; low and high end bracket the measured number.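

In this assay, methyl in place of hydrogen on an aromatic carbon gave a number 14.2 percentage points lower from compound 1 to compound 4 (beyond the scatter), and this step does not agree with the earlier one: the same change on two cores in this assay, a number 9.6 percentage points higher (within the scatter) from compound 2 to compound 3 and a number 14.2 percentage points lower (beyond the scatter) from compound 1 to compound 4, 23.8 percentage points apart, beyond the scatter of two such steps. This shows that the result of this change on one core cannot simply be carried over to another in this series. It does not show what separates the two steps, for the cores differ and the methyl does not stand at the same place on the ring in compound 3 and compound 4, so core and place cannot be told apart, and two steps give no rule for the series.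

The compounds shown leave open how a methyl at the same place as in compound 4 would act on the core of compound 2, and how a methyl at the place it holds in compound 3 would act on the core of compound 1. They also leave open what an ethyl, a methoxy group or an amine would do in place of the methyl.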